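Bis-arylidene piperidone fumaramides: aryl amide swap on the nitro pair

The source may report more compounds than this note shows. Statements on the series, on what has been measured and on what is new or still open speak of the compounds shown alone.

Within the data shown here, compound 1 `CC(=O)c1ccc(NC(=O)/C=C/C(=O)N2C/C(=C\c3ccc([N+](=O)[O-])cc3)C(=O)/C(=C/c3ccc([N+](=O)[O-])cc3)C2)cc1` is the stronger of the two measured members. In a functional assay on CCRF-CEM cells (Homo sapiens) for cytotoxicity (a lower number here means a stronger inhibitor, a higher number a weaker inhibitor), compound 1 gives 360 nM. Among the measured compounds shown here, compound 2 `Cc1ccc(NC(=O)/C=C/C(=O)N2C/C(=C\c3ccccc3)C(=O)/C(=C/c3ccccc3)C2)cc1` carries plain phenyl arms on the shared core and a 4-methylphenyl amide, and in this assay compound 2 gives 1100 nM; the two values differ in a way that lies beyond the usual scatter, but since compound 1 and compound 2 differ in two places at once, the pair shows only that the combination in compound 1 comes out lower.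

Compound 3 `Cc1ccc(NC(=O)/C=C/C(=O)N2C/C(=C\c3ccc([N+](=O)[O-])cc3)C(=O)/C(=C/c3ccc([N+](=O)[O-])cc3)C2)cc1C` keeps the nitro-bearing arms of compound 1 and changes the amide end: 3,4-dimethylphenyl in place of 4-acetylphenyl on an amide-type nitrogen. For the measured compounds named here, no single-site step is available to calibrate this change. The nearest information is the 4-methylphenyl amide of compound 2, which sits together with a different arm pattern. A modest loss, or no change beyond the scatter, is expected, giving the step of a 1.5-fold higher number from compound 1 to compound 3 (0.18 log units; within the scatter). For compound 3 in this assay the expected value is 550 nM, with a range from 200 nM to 1500 nM.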

Compound 3, half-maximal inhibitory concentration: 700 nM
The estimate for compound 3 lay 1.3-fold (0.10 log units) below the measured number; the measured number falls inside the stated range.
By their numbers in this assay, from the lowest: compounds 1, 3 and 2 (each within the scatter of the next, the first and the last beyond it).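

In this assay, among these compounds, the step of a 1.9-fold higher number from compound 1 to compound 3 (0.29 log units; within the scatter) is the first single-site reading: with the nitro-bearing arms held fixed, 3,4-dimethylphenyl stands in place of 4-acetylphenyl on an amide-type nitrogen. The swap removes the hydrogen-bond acceptor and the double bond outside aromatic rings counted on the leaving group, and the printed step stays within the scatter, so for this pair the amide end accepts either aryl group without a difference that can be read. Nothing available accounts for this result or links it to any property of the two groups.

Among the compounds shown here, the contribution of the arms remains open, as no single-site step yet compares the nitro-bearing arms with plain phenyl arms at a fixed amide end. Also open, going by these compounds, is how this assay would read for an amine or a carboxylic acid on the amide aryl group, or for a longer alkyl chain in place of that aryl group on the amide-type nitrogen.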